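Amide nitrogen substituents on a shared core in paw edema

The compounds below may be only part of what the source reports. "The series", "measured", "known", "first", "only" and "open" are said of these compounds alone.

Measured compounds:
compound 1 `O=C(NCc1ccccc1)c1c(O)c2cccnc2n(-c2ccccc2)c1=O`: 11.3%
compound 2 `Nc1ccc(NC(=O)c2c(O)c3cccnc3n(-c3ccccc3)c2=O)cc1`: 0%

In a functional assay on the whole organism for inhibition, with Rattus norvegicus as the target, read by cytopathic effect and paw edema, at a dose of 100 mg/kg by the oral route (a lower number here means less inhibition, a higher number more inhibition at the dose given (going by the name of the read-out)), compound 1 stands highest of the two numbers; compound 2 lies a number 11.3 percentage points lower from compound 1 to compound 2 (beyond the scatter). Compound 3 `O=C(Nc1ccc(Cl)nc1)c1c(O)c2cccnc2n(-c2ccccc2)c1=O` is not yet measured. It differs from compound 1 by 6-chloropyridin-3-yl in place of benzyl on an amide-type nitrogen. Within the data shown here, the one step that bears on this is that from benzyl to an aryl group on the same nitrogen, which gave a number 11.3 percentage points lower from compound 1 to compound 2 (beyond the scatter). A downward step is therefore expected, a number 8.3 percentage points lower from compound 1 to compound 3 (within the scatter), and compound 3 is estimated at 3%, within 0% to 15%.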

Compound 3, a percentage reported as inhibition, in the whole organism at one dose (the size of the read-out at that dose, not a potency): -4%
Compound 3: the middle estimate sits 7 percentage points above what was measured; the whole stated range lies above it.
By their numbers in this assay, from the lowest: compounds 3 and 2 (each within the scatter of the next); then compound 1.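

In this assay, a second ring group set directly on the amide-type nitrogen also falls short of benzyl: 6-chloropyridin-3-yl in its place gives a number 15.3 percentage points lower from compound 1 to compound 3 (beyond the scatter). Exchanging 4-aminophenyl for 6-chloropyridin-3-yl gives a number 4 percentage points lower from compound 2 to compound 3 (within the scatter), so these two groups cannot be told apart here, although their rings differ. No evidence bearing on this result is available. From the compounds shown here alone, whether a phenethyl or cyclohexyl group on this nitrogen would match compound 1 remains open, as does whether a pyridylmethyl group would retain its level.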